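Swapping Iodo for Nitro on a Ring: Expecting Compound 4

A few compounds are considered here, and "the series" means these few. Any claim that something is new, unique, unknown or untested is made for them only; others in the source may bear on it.

Compound 1 has the structure `C/C(=N\NC(=S)Nc1ccccc1I)c1ccccn1` and, in a functional assay on U-87MG ATCC cells (Homo sapiens) for cytotoxicity, read by MTT assay, with a stated time of 48 h (on this read-out lower numbers stand for stronger inhibition and higher numbers for weaker inhibition), compound 1 gives 6.1 nM. Compound 3, with the structure `C/C(=N\NC(=S)Nc1ccccc1[N+](=O)[O-])c1ccccn1`, differs from compound 1 by a single change, (nitro in place of iodo on an aromatic carbon), and in this assay compound 3 gives 4.3 nM; the step is a 1.4-fold lower number from compound 1 to compound 3 (0.15 log units; within the scatter). Compound 2, with the structure `C/C(=N\NC(=S)Nc1cccc(I)c1)c1ccccn1`, is built from the same atoms as compound 1 joined differently; the difference between the two cores is not broken down here. In this assay compound 2 gives 84 nM, the highest number of the three, beyond the scatter from both compound 1 and compound 3.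

Compound 4, with the structure `C/C(=N\NC(=S)Nc1cccc([N+](=O)[O-])c1)c1ccccn1`, has not yet been measured. It differs from compound 2 by nitro in place of iodo on an aromatic carbon. Going by the values given here, this is the same kind of change as the one from compound 1 to compound 3, but the place differs: there the nitro stood ortho to a large group, here it stands meta to a large group. Because a 1.4-fold lower number from compound 1 to compound 3 (0.15 log units; within the scatter) stayed within the scatter, the step from compound 2 to compound 4 is expected to be small as well, about a 1.2-fold lower number from compound 2 to compound 4 (0.08 log units; within the scatter). Compound 4 is therefore expected to give about 70 nM, most likely between 20 nM and 250 nM.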

Compound 4, half-maximal inhibitory concentration: 69 nM
The estimate for compound 4 lay 1.0-fold (0.01 log units) above the measured number; low and high end bracket the measured number.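

In this assay, the swap of iodo for nitro again leaves the number almost unchanged, with a 1.2-fold lower number from compound 2 to compound 4 (0.09 log units; within the scatter). Set side by side, the two cases show that in this series the change carries over from one core to the other with much the same small size: the same change on two cores in this assay, a 1.4-fold lower number (0.15 log units; within the scatter) from compound 1 to compound 3 and a 1.2-fold lower number (0.09 log units; within the scatter) from compound 2 to compound 4, 1.2-fold (0.07 log units) apart, within the scatter of two such steps. Going by these compounds alone, this rests on only two pairs in a single cell assay, so it does not show that nitro and iodo can be exchanged freely on other cores or in other tests, and it does not explain why the step stays so small in either pair.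

The compounds shown leave open whether a quite different group on the same ring, such as an amine, a carboxylic acid or a longer chain, would also leave the number almost unchanged. They also leave open whether the swap of iodo for nitro would stay this small at any other place on that ring.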